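The source may hold more compounds than are shown below. What is called first, only, known or untested is meant among the compounds shown, and "the series" means these compounds.

Measured compounds:
compound 1, `CCNC(=O)c1cc(Oc2ccc(NC(=O)c3cc4cccnc4n(-c4ccc(Br)cc4)c3=O)cc2)ccn1`, 1160 nM
compound 2, `CCNC(=O)c1cc(Oc2ccc(NC(=O)c3cc4cccnc4n(-c4ccc(Br)cc4F)c3=O)cc2)ccn1`, 2070 nM
compound 3, `CCCNC(=O)c1cc(Oc2ccc(NC(=O)c3cc4cccnc4n(-c4ccccc4)c3=O)cc2)ccn1`, 98 nM

Three compounds carry a measurement in a functional assay on HT-29 cells (Homo sapiens) for antiproliferative activity, read by MTT assay, with a stated time of 72 h; on this read-out lower numbers stand for stronger inhibition and higher numbers for weaker inhibition. Compound 1 and compound 2 share a core and differ at one place: fluoro in place of hydrogen on an aromatic carbon. This change gave a 1.8-fold higher number from compound 1 to compound 2 (0.25 log units; within the scatter), so the two values cannot be told apart with confidence. Compound 3 has a different core; how the core of compound 3 differs from the core of compound 1 is not broken down here. Its value stands lowest of the three; compound 1 and compound 2 both give higher numbers, and both differences lie beyond the scatter.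

Compound 4, `CCCNC(=O)c1cc(Oc2ccc(NC(=O)c3cc4cccnc4n(-c4ccccc4F)c3=O)cc2)ccn1`, has not yet been measured in this assay. It differs from compound 3 in one place: fluoro in place of hydrogen on an aromatic carbon. This is the same kind of change as that from compound 1 to compound 2, though not the same: in compound 2 the entering fluoro sits ortho to a large group and meta to a bromo group, whereas in compound 4 it sits ortho to a large group only, on a ring that carries no bromo. For the measured compounds named here, the one measured example of this kind of change gave a 1.8-fold higher number from compound 1 to compound 2 (0.25 log units; within the scatter), and so compound 4 is expected to give a step of about a 1.6-fold higher number from compound 3 to compound 4 (0.21 log units; within the scatter), resting on that single precedent. Compound 4 is therefore estimated at 160 nM, expected to fall between 60 nM and 420 nM.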

Compound 4, half-maximal inhibitory concentration: 200 nM
Compound 4: the middle estimate sits 1.3-fold (0.10 log units) below what was measured, and the stated range covers the measured number.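

In this assay, putting fluoro in place of hydrogen on the phenyl ring of compound 3 gave a 2.0-fold higher number from compound 3 to compound 4 (0.31 log units; beyond the scatter), a modest step. Set beside the one earlier example, the change carried from one core to the other with much the same size: the same change on two cores in this assay, a 1.8-fold higher number (0.25 log units; within the scatter) from compound 1 to compound 2 and a 2.0-fold higher number (0.31 log units; beyond the scatter) from compound 3 to compound 4, 1.1-fold (0.06 log units) apart, within the scatter of two such steps. For the compounds shown here, this rests on only two pairs, and only the step on the core of compound 3 lies beyond the scatter, so the agreement shows a similar size on these two cores but neither predicts the step on a further core nor explains why it has this size.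

The compounds shown leave open whether fluoro at another place on the ring, or a different group such as chloro, methoxy or a nitrile ortho to a large group, would give a similar step. They also leave open what the bromo group and the chain on the amide each contribute on their own, and whether a longer chain or an amine at that end of the molecule would change the numbers in this series.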